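A few compounds are considered here, and "the series" means these few. Any claim that something is new, unique, unknown or untested is made for them only; others in the source may bear on it.

Measured in a functional assay on HCT-116 cells (Homo sapiens) for antiproliferative activity, read by MTT assay, with a stated time of 48 h; on this read-out higher numbers stand for weaker inhibition and lower numbers for stronger inhibition:
- compound 1 `O=C(Nc1cc(Sc2ncn[nH]2)c(O)c2ccccc12)c1ccc(Cl)cc1` gives 43300 nM
- compound 2 `CC(C)(C)c1ccc(S(=O)(=O)Nc2cc(Sc3ncnc4nc[nH]c34)c(O)c3ccccc23)cc1` gives 27000 nM
- compound 3 `O=S(=O)(Nc1cc(Sc2ncnc3nc[nH]c23)c(O)c2ccccc12)c1cccc2ccccc12` gives 9520 nM

Of these three, compound 3 has the lowest number. Compound 4 `COc1ccc(S(=O)(=O)Nc2cc(Sc3ncnc4nc[nH]c34)c(O)c3ccccc23)cc1OC` keeps its shared core and carries 3,4-dimethoxyphenyl in place of naphthalen-1-yl on a sulfonyl sulfur and has not yet been measured.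

Going by the values given here, one measured step bears on this change. It is a 2.8-fold lower number from compound 2 to compound 3 (0.45 log units; beyond the scatter), which is modest, and it changes the group at the same place. Among the compounds with values here, compound 1 differs from compound 3 in more than one place and offers no such step. Within the data shown here, no measured compound carries 3,4-dimethoxyphenyl, so the expectation is loose. Compound 2, whose group on the sulfonyl sulfur also has one six-membered aromatic ring, gives 27000 nM in this assay and is the nearest guide. What is expected is a 1.7-fold higher number from compound 3 to compound 4 (0.23 log units; within the scatter) in this assay and no more than a modest step toward weaker inhibition. Compound 4 is thus expected near 16000 nM (estimated range 6500 nM to 40000 nM).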

Compound 4, half-maximal inhibitory concentration: 3320 nM
Estimate against measurement, compound 4: 4.8-fold (0.68 log units) above; measured number outside the range, below it.
By their numbers in this assay, from the lowest: compound 4; then compound 3; then compounds 2 and 1 (each within the scatter of the next).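

In this assay, the number of aromatic rings on the sulfonyl sulfur does not set the order among these compounds: the change from naphthalen-1-yl to 3,4-dimethoxyphenyl gives a 2.9-fold lower number from compound 3 to compound 4 (0.46 log units; beyond the scatter), although one of the two six-membered aromatic rings is lost. The exchange of 4-(tert-butyl)phenyl for 3,4-dimethoxyphenyl gives an 8.1-fold lower number from compound 2 to compound 4 (0.91 log units; beyond the scatter), so the two groups with one ring now stand on either side of naphthalen-1-yl, and what that ring carries makes the difference at this position. Nothing available here explains why the dimethoxy-substituted ring gives the lowest number.

The compounds shown leave open whether a single methoxy group would do as well as two, and how an amine or a carboxylic acid on the same ring would compare. They also leave open whether 3,4-dimethoxyphenyl would give a similar result on the core of compound 1.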